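Bromo substitution across two aryl cores: growth inhibition notes

A few compounds are considered here, and "the series" means these few. Any claim that something is new, unique, unknown or untested is made for them only; others in the source may bear on it.

Measured so far in a functional assay on MCF7 cells (Homo sapiens) for cytotoxicity, read by sulforhodamine B assay, with a stated time of 48 h; on this read-out higher numbers stand for weaker inhibition of growth and lower numbers for stronger inhibition of growth:
compound 1 `COc1cc(/C(Cl)=C/C=C(\C#N)C(=O)c2c[nH]c3ccccc23)cc(OC)c1OC`, 94300 nM
compound 2 `COc1cc(/C(Cl)=C/C=C(\C#N)C(=O)c2c[nH]c3ccc(Br)cc23)cc(OC)c1OC`, 96500 nM
compound 3 `COc1ccc(/C(Cl)=C/C=C(\C#N)C(=O)c2c[nH]c3ccccc23)cc1OC`, > 100000 nM, which is a limit of this assay and not a number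

Compound 1 and compound 2 differ by bromo in place of hydrogen on an aromatic carbon, and the step is a 1.0-fold higher number from compound 1 to compound 2 (0.01 log units; within the scatter). Compound 1 and compound 3 differ in their cores by hydrogen in place of methoxy on an aromatic carbon, giving an at least 1.0-fold higher number from compound 1 to compound 3 (0.02 log units; that floor lies within the scatter); the reading for compound 3 sits at the limit of > 100000 nM in this assay, at which 1 of the 3 values shown sits.

Compound 4 `COc1ccc(/C(Cl)=C/C=C(\C#N)C(=O)c2c[nH]c3ccc(Br)cc23)cc1OC` is not yet measured in this assay. It differs from compound 3 by bromo in place of hydrogen on an aromatic carbon, the same change as from compound 1 to compound 2, at the same place. The step is expected to be a step that the limit leaves unreadable from compound 3 to compound 4, resting on the earlier step of a 1.0-fold higher number from compound 1 to compound 2 (0.01 log units; within the scatter) lying within the scatter. Compound 4 is therefore expected near 110000 nM, between 60000 nM and 250000 nM, quite possibly reported again as a limit in this assay.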

Compound 4, concentration for total growth inhibition: > 100000 nM
Compound 4 gave a limit, no number; the forecaster's own chance of this, stated with the estimate: 65%; the middle value is on the limit's open side.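

The step for bromo in place of hydrogen on the core of compound 3 cannot be read, as compound 3 and compound 4 both stand at a limit, so this neither confirms nor rules out that the result from compound 1 to compound 2 carries over to this core. In this assay, with bromo present, hydrogen in place of methoxy gives an at least 1.0-fold higher number from compound 2 to compound 4 (0.01 log units; that floor lies within the scatter), and this change compares with the same change without bromo only through floors: the same change on two cores in this assay, an at least 1.0-fold higher number (0.02 log units; that floor lies within the scatter) from compound 1 to compound 3 and an at least 1.0-fold higher number (0.01 log units; that floor lies within the scatter) from compound 2 to compound 4; the limit leaves it open whether they differ. The limit constrains every such comparison: the limit of > 100000 nM in this assay, at which 2 of the 4 values shown sit.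

From the compounds shown here alone, whether the two cores would separate beyond the limit remains open. Also open, going by these compounds, is how an amine or a carboxylic acid in place of bromo would read on either core.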